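Phenyl in place of 1,3-thiazol-4-yl in compound 3

This account rests on a few compounds, and the source may have more. Where it says the series, first, only, none or still open, it means among the compounds named here.

Among the compounds with values here, in a functional assay on A-375 cells (Homo sapiens) for activation, with a stated time of 3 days (a lower number here means that less compound is needed, a higher number that more compound is needed for the effect), compound 1 `O=C(Nc1ccc(-c2cscn2)cc1)C1CCCN(Cc2ccc(F)c(F)c2)C1` gives 1240 nM as the only true number so far. Compound 2 `O=C(Nc1ccc(-c2cscn2)cc1)C1CCCN(Cc2cccnc2)C1` reads > 20000 nM and that is a limit of the assay. Compound 3 `O=C(Nc1ccc(-c2ccccc2)cc1)C1CCCN(Cc2ccc(F)c(F)c2)C1` puts phenyl in place of 1,3-thiazol-4-yl on an aromatic carbon and keeps the rest of compound 1. Within the data shown here, the one measured step of an at least 16-fold higher number from compound 1 to compound 2 (1.20 log units; beyond the scatter) is large but changes another place, with pyridin-3-yl in place of 3,4-difluorophenyl, so it says little here. No step beyond the scatter is expected in this assay and the estimated change is a 1.2-fold higher number from compound 1 to compound 3 (0.08 log units; within the scatter) with no firm direction. For compound 3 the expected value is 1500 nM with an estimated range from 400 nM to 6000 nM around it.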

Compound 3, half-maximal effective concentration: 5000 nM
The estimate for compound 3 lay 3.3-fold (0.52 log units) below the measured number; the range from low to high includes it.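

In this assay, the place on the six-membered aromatic ring that carries 1,3-thiazol-4-yl turns out to matter: swapping that group for phenyl gives a 4.0-fold higher number from compound 1 to compound 3 (0.61 log units; beyond the scatter). Within the data shown here, the earlier step changed a different place, so this is the first sign that more compound is needed when this ring changes. Nothing shown here accounts for the step.

As far as these compounds go, whether the sulfur or the nitrogen of 1,3-thiazol-4-yl counts for more remains open. Thiophen-3-yl or oxazol-4-yl at this place could separate the two.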